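A Second Chloro Group on Two Related Cores

A few compounds are considered here, and "the series" means these few. Any claim that something is new, unique, unknown or untested is made for them only; others in the source may bear on it.

Measured compounds:
compound 1, `ClCc1ccc(Cn2cnc3c(Cl)ncnc32)cc1`, 9230 nM
compound 2, `ClCc1cccc(Cn2cnc3ncnc(Cl)c32)c1`, 20000 nM
compound 3, `ClCc1ccc(Cn2cnc3c(Cl)nc(Cl)nc32)cc1`, 34700 nM

All three were tested in a functional assay on OVCAR-5 cells (Homo sapiens) for cytotoxicity, read by sulforhodamine B assay, with a stated time of 48 h; on this read-out higher numbers stand for weaker inhibition of growth and lower numbers for stronger inhibition of growth. Compound 1 and compound 2 have the same atoms joined differently; the difference between the two cores is not broken down here. In this assay compound 1 gives 9230 nM, while compound 2 gives 20000 nM. Compound 3 differs from compound 1 by chloro in place of hydrogen on an aromatic carbon, and this change brought a 3.8-fold higher number from compound 1 to compound 3 (0.58 log units; beyond the scatter).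

Compound 4, `ClCc1cccc(Cn2cnc3nc(Cl)nc(Cl)c32)c1`, has not yet been measured in this assay. Among the measured compounds shown here, it differs from compound 2 by chloro in place of hydrogen on an aromatic carbon, which is the same change as the one from compound 1 to compound 3. For the measured compounds named here, since that single earlier step is the only guide available, compound 4 is expected to show a 3.5-fold higher number from compound 2 to compound 4 (0.54 log units; beyond the scatter). Compound 4 is therefore estimated at 70000 nM, within a range from 30000 nM to 160000 nM, an expectation that rests on one step alone and so remains uncertain.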

Compound 4, concentration for total growth inhibition: 3230 nM
The estimate for compound 4 lay 22-fold (1.34 log units) above the measured number, and the stated range ends above it.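

In this assay, the second chloro group on the core of compound 2 brought a 6.2-fold lower number from compound 2 to compound 4 (0.79 log units; beyond the scatter) and so moved the number the opposite way from the same change on the core of compound 1. The two steps do not agree: the same change on two cores in this assay, a 3.8-fold higher number (0.58 log units; beyond the scatter) from compound 1 to compound 3 and a 6.2-fold lower number (0.79 log units; beyond the scatter) from compound 2 to compound 4, 23-fold (1.37 log units) apart, beyond the scatter of two such steps

Within these four compounds, then, the effect of chloro in place of hydrogen measured on one core did not carry over to the other, in either direction or size. Among the compounds shown here, this does not show why the two cores part ways, and with only one pair on each core it gives no general rule for either of them.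

The compounds shown leave open whether an amine or a methoxy group on the aromatic carbon between two ring nitrogen atoms would also separate the two cores. They also leave open whether the two cores would still differ if the chloromethyl group gave way to a hydroxymethyl group.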